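The compounds below may be only part of what the source reports. "The series", "measured", "known", "first", "only" and "open" are said of these compounds alone.

In an ADME assay on HepG2 cells (Homo sapiens) for cytotoxicity, read by CellTiter-Glo, with a stated time of 72 h (on this read-out lower numbers stand for an effect already at smaller amounts and higher numbers for an effect only at larger amounts of compound), compound 1 `C/C1=C/C2=C[C@H](C)C[C@@]23O[C@]2(CC(C)(C)C[C@@H]2[C@@]1(O)C(F)(F)F)[C@@H](C)C3=O` gives 26000 nM and compound 2 `CC1=C2CC(C)(C)/C=C/C(=O)/C(C)=C\C3=C[C@H](C)C[C@]3(O2)[C@@]1(O)C(F)(F)F` gives 26000 nM, which places compound 2 level with compound 1. Compound 3 `CC1=C2CC(C)(C)/C=C/C(=O)/C(C)=C\C3=C[C@H](C)C[C@]3(O2)[C@]1(C)O` has not yet been measured. Compound 3 has methyl in place of trifluoromethyl on a saturated ring carbon. Among the measured compounds shown here, no measured pair shows the effect of this change, so no step beyond the scatter is expected in this assay, in either direction. The estimated step is a 1.2-fold lower number from compound 2 to compound 3 (0.07 log units; within the scatter). The expected value for compound 3 is 22000 nM, with an estimated range of 8000 nM to 50000 nM.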

Compound 3, half-maximal effective concentration: 26000 nM
Compound 3: middle estimate off by 1.2-fold (0.07 log units), on the low side, within the range that was stated.
By their numbers in this assay, from the lowest: compounds 1, 2 and 3 (each within the scatter of the next).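

In this assay, among the compounds shown here, the exchange of trifluoromethyl for methyl on this saturated ring carbon gives no change at the digits printed from compound 2 to compound 3 (within the scatter) and is the first change at this position that can be read. At this position and on this core, the read-out therefore does not separate the two groups. Nothing on hand explains this result.

As far as these compounds go, whether an amine, a carboxylic acid or a longer chain on this carbon would leave the number equally unmoved remains open. From the compounds shown here alone, it also remains open whether methyl and trifluoromethyl would read alike on the core of compound 1.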